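A few compounds are considered here, and "the series" means these few. Any claim that something is new, unique, unknown or untested is made for them only; others in the source may bear on it.

Compound 2 `CC(=O)N1CCC(n2cc(-c3cnc(N)c4oc(-c5cccc6cnsc56)cc34)cn2)CC1` is the stronger of two measured compounds: in an ADME assay on microsomes from liver (Homo sapiens) for metabolic stability (on this read-out higher numbers stand for higher hepatic extraction and lower numbers for lower hepatic extraction), compound 2 gives 0.73, while compound 1 `CC(=O)N1CCC(n2cc(-c3cnc(N)c4oc(-c5cnc6cnccn56)cc34)cn2)CC1` gives 0, and the step a number 0.73 higher from compound 1 to compound 2 (beyond the scatter) is large. Compound 3 `CC(=O)N1CCC(n2cc(-c3cnc(N)c4oc(-c5csc6ccccc56)cc34)cn2)CC1` differs from compound 2 by a group of 9 heavy atoms (8 carbon, 1 sulfur; one five-membered aromatic ring with 1 hetero atom, one six-membered aromatic ring of carbon only) in place of a group of 9 heavy atoms (7 carbon, 1 nitrogen, 1 sulfur; one five-membered aromatic ring with 2 hetero atoms, one six-membered aromatic ring of carbon only), on an aromatic carbon. Among the measured compounds shown here, the only comparable step, the swap of one fused two-ring group for another on the same aromatic carbon from compound 1 to compound 2, was large and upward. For compound 3 a smaller upward step or none beyond the scatter is expected, estimated at a number 0.070 higher from compound 2 to compound 3 (within the scatter). Compound 3 is thus expected to give 0.8, between 0.6 and 0.95.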

Compound 3, hepatic extraction ratio: 0.68
For compound 3 the middle estimate is 0.12 above the measured one; the measured number falls inside the stated range.
By their numbers in this assay, from the lowest: compound 1; then compounds 3 and 2 (each within the scatter of the next).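

At this position, on an aromatic carbon next to the ring oxygen, the swap to 1-benzothiophen-3-yl gives a number 0.050 lower from compound 2 to compound 3 (within the scatter) in this assay, so the nitrogen of the five-membered ring in the group that leaves makes no difference beyond the scatter here. The step a number 0.68 higher from compound 1 to compound 3 (beyond the scatter) is large, and so a second group with a six-membered ring of carbon only stands far from compound 1, whose six-membered ring holds 2 hetero atoms. Nothing shown gives a reason for these numbers. As far as these compounds go, it remains open how a single phenyl ring or a pyridine ring would read at this carbon. From the compounds shown here alone, an amine there is equally open.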